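The source may report more compounds than this note shows. Statements on the series, on what has been measured and on what is new or still open speak of the compounds shown alone.

Working notes on the series. Compound 1 `COc1ncc(-c2ccc3nccc(-c4ccc(C)cc4)c3c2)cc1NS(=O)(=O)c1ccc(F)cc1F` carries hydrogen on a saturated chain carbon bound to an aromatic carbon, where compound 2 `COc1ncc(-c2ccc3nccc(-c4ccc(CN5CCCCC5)cc4)c3c2)cc1NS(=O)(=O)c1ccc(F)cc1F` carries piperidin-1-yl. In a functional assay on A549 cells (Homo sapiens) for cytotoxicity, read by MTT assay, with a stated time of 72 h (a higher number here means a weaker inhibitor, a lower number a stronger inhibitor), compound 1 gives 1240 nM and compound 2 gives 15.5 nM. Among the compounds with values here, the only measured step, an 80-fold lower number from compound 1 to compound 2 (1.90 log units; beyond the scatter), is large, and compound 2 holds the lower of the two numbers in this assay, with compound 1 the only neighbour. Compound 3 `COc1ncc(-c2ccc3nccc(-c4ccc(CN5CCN(C)CC5)cc4)c3c2)cc1NS(=O)(=O)c1ccc(F)cc1F` is not yet measured; its change from compound 2 is 4-methylpiperazin-1-yl in place of piperidin-1-yl on a saturated chain carbon bound to an aromatic carbon. Within the data shown here, the single measured step concerns the introduction of piperidin-1-yl in place of hydrogen, not the exchange of one ring for another, and it bears on compound 3 only in that a six-membered non-aromatic ring on the saturated chain carbon is retained. Among the measured compounds shown here, no measured pair separates piperidin-1-yl from 4-methylpiperazin-1-yl. For compound 3 the step from compound 2 is therefore expected to stay within the scatter, a 1.3-fold higher number from compound 2 to compound 3 (0.11 log units; within the scatter). Compound 3 is estimated at 20 nM in this assay, with a range from 6 nM to 65 nM.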

Compound 3, half-maximal inhibitory concentration: 13.3 nM
For compound 3 the middle estimate is 1.5-fold (0.18 log units) above the measured one; the measured number falls inside the stated range.
By their numbers in this assay, from the lowest: compounds 3 and 2 (each within the scatter of the next); then compound 1.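

In this assay, exchanging the ring on the saturated chain carbon bound to an aromatic carbon gives a 1.2-fold lower number from compound 2 to compound 3 (0.07 log units; within the scatter), so piperidin-1-yl and 4-methylpiperazin-1-yl cannot be told apart at this position, despite the additional ring nitrogen and its methyl. The large step from hydrogen is also no longer tied to piperidin-1-yl alone: a 93-fold lower number from compound 1 to compound 3 (1.97 log units; beyond the scatter) stands alongside an 80-fold lower number from compound 1 to compound 2 (1.90 log units; beyond the scatter), and both lie beyond the scatter, so two different six-membered non-aromatic rings on this carbon share that large step. No evidence is available on what underlies either the large steps or the absence of a separation between the two rings.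

The compounds shown leave open whether a ring is needed at all, which an open-chain amine such as diethylamino on the same carbon would address, and whether the ring nitrogen matters, which cyclohexyl would address. Going by these compounds, it also remains open how far this tolerance extends, for example to morpholin-4-yl, to a carboxylic acid, or to a longer chain between the aromatic carbon and the ring.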